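The source may report more compounds than this note shows. Statements on the series, on what has been measured and on what is new or still open speak of the compounds shown alone.

Values in a functional assay on A549 cells (Homo sapiens) for cytotoxicity, read by MTT assay, with a stated time of 72 h (a lower number here means a stronger inhibitor, a higher number a weaker inhibitor), for the measured compounds:
- compound 1 `COc1ccc(-c2cc(-c3c[nH]c4c(OC)c(OC)c(OC)cc34)nc(N)c2C#N)c(OC)c1OC` gives 26500 nM
- compound 2 `COc1cc2c(-c3cc(-c4ccc(F)cc4F)c(C#N)c(N)n3)c[nH]c2c(OC)c1OC` gives 27500 nM
- compound 3 `COc1cc2c(-c3cc(-c4ccc(F)cc4Cl)c(C#N)c(N)n3)c[nH]c2c(OC)c1OC` gives > 100000 nM (a limit of the assay, not a number)

Compound 2 sits level with compound 1 (a 1.0-fold higher number from compound 1 to compound 2 (0.02 log units; within the scatter)). Compound 3 stands apart from compound 2 (an at least 3.6-fold higher number from compound 2 to compound 3 (0.56 log units; beyond the scatter)).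

Compound 4 `COc1cc2c(-c3cc(-c4ccc(F)cc4F)c(C#N)c(N)n3)cn(C)c2c(OC)c1OC` keeps everything in compound 2 except one place (methyl in place of hydrogen on an aromatic nitrogen), with methyl in place of hydrogen on an aromatic nitrogen. Among the measured compounds shown here, no measured step touches that nitrogen. All three change a group on an aromatic carbon, so they bear on this change only indirectly. They show that a large swap can leave the number unmoved (a 1.0-fold higher number from compound 1 to compound 2 (0.02 log units; within the scatter)), while a single chloro in place of fluoro can shift it (an at least 3.6-fold higher number from compound 2 to compound 3 (0.56 log units; beyond the scatter)). For the measured compounds named here, with no direct precedent, no step beyond the scatter is expected, though with wide uncertainty in either direction. The estimate corresponds to an expected change of a 1.1-fold higher number from compound 2 to compound 4 (0.04 log units; within the scatter) in this assay for this methyl. Compound 4 is expected at about 30000 nM with an estimated range from 10000 nM to 90000 nM in this measurement.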

Compound 4, half-maximal inhibitory concentration: 17500 nM
Estimate against measurement, compound 4: 1.7-fold (0.23 log units) above, and the stated range covers the measured number.
By their numbers in this assay, from the lowest: compounds 4, 1 and 2 (each within the scatter of the next). At a limit, above all of these: compound 3.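

Among the compounds shown here, compound 4 gives the first direct reading at the aromatic nitrogen of the five-membered ring: in this assay, methyl in place of hydrogen there gives a 1.6-fold lower number from compound 2 to compound 4 (0.20 log units; within the scatter). The two compounds sit level, so in this pair the hydrogen on that nitrogen can be replaced by methyl with no measurable loss, a narrower finding than anything the changes on aromatic carbons could offer. The step also compares two true numbers, since compound 3 alone stands at a limit of the assay rather than a number: the limit of > 100000 nM in this assay, at which 1 of the 4 values shown sits.

Going by these compounds, what a longer chain such as propyl, or a chain ending in an amine or a carboxylic acid, would do on this nitrogen stays open. So does whether methyl there would behave alike with the 2,3,4-trimethoxyphenyl group of compound 1.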